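Methoxy to methanesulfonate on a pyridyl alkyne

The source may report more compounds than this note shows. Statements on the series, on what has been measured and on what is new or still open speak of the compounds shown alone.

Measured compounds:
Compound 1 `Cc1nc(C#Cc2cccc(C(F)(F)F)c2)cs1` gives 413 nM in a functional assay on CHO cells for agonist activity at metabotropic glutamate receptor 5 (Homo sapiens), read by inositol phosphate accumulation; a lower number here means a stronger inhibitor, a higher number a weaker inhibitor.
Compound 2 `COc1ncccc1C#Cc1csc(C)n1` gives 228 nM in this assay.

Two compounds share the alkyne-linked thiazole core and differ only in the aromatic ring at the far end of the alkyne. Of the two numbers, compound 2 holds the lower one, and the nearest neighbour is compound 1, whose value sits within the usual scatter of this kind of measurement; the two therefore cannot be ranked against each other.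

Compound 3 `Cc1nc(C#Cc2cccnc2OS(C)(=O)=O)cs1` has not yet been measured. It is derived from compound 2 by a single change: methylsulfonyl in place of methyl on an oxygen on an aromatic ring. Read one bond further out, the methoxy of compound 2 becomes a (methylsulfonyl)oxy group. Within the data shown here, no measured pair shows this exchange, so its effect can only be guessed.

Compound 3 is expected to sit somewhat weaker than compound 2, with a step of a 2.4-fold higher number from compound 2 to compound 3 (0.38 log units; beyond the scatter) anticipated in this assay, a change that may or may not clear the scatter. The estimate for compound 3 is 550 nM, with a plausible range from 150 nM to 2500 nM.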

Compound 3, half-maximal inhibitory concentration: > 10000 nM
Compound 3 was reported as a limit; the forecaster's own chance of this, stated with the estimate: 15%; middle value at least 18-fold (1.25 log units) from the limit.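

Among these compounds, replacing methoxy with (methylsulfonyl)oxy is the first single-place change seen, and in this assay it produces an at least 43-fold higher number from compound 2 to compound 3 (1.64 log units; beyond the scatter), a large step beyond the scatter. From the compounds shown here alone, the reading of > 10000 nM for compound 3 is a limit and not a number, so this step gives only the smallest size the change could have, and the true value of compound 3 stays unknown: the limit of > 10000 nM in this assay, at which 1 of the 3 values shown sits. The position is therefore far from indifferent to what sits on this oxygen on an aromatic ring, since methyl there in compound 2 gives a measured value, while methylsulfonyl in compound 3 gives only a limit, something that the comparison of compound 1 with compound 2, which differ at the far end of the alkyne and stand within the scatter of each other, could not reveal.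

The compounds shown leave open whether an ethyl group on this oxygen, or an amine in place of the oxygen, would keep a measurable value in this assay. With a single exchange at this position, they also cannot tell which part of the methylsulfonyl group accounts for the step.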